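Extending the aromatic alkyl chain from compound 2 to compound 4

A few compounds are considered here, and "the series" means these few. Any claim that something is new, unique, unknown or untested is made for them only; others in the source may bear on it.

Three ureas have been measured in an ADME assay on the whole organism with Oryza sativa as the target, tested at 1 uM; a higher number here means a weaker effect of the compound at the concentration tested, a lower number a stronger effect. Compound 1 `CC(C)c1ccc(NC(=O)N[C@@H](C)c2ccccc2)cc1` gives 96%, compound 3 `CCCc1ccc(NC(=O)N[C@@H](C)c2ccccc2)cc1` gives 76%, and compound 2 `CCCc1ccc(NC(=O)N[C@H](C)c2ccccc2)cc1` gives 31%, the lowest of the three numbers. The step from compound 1 to compound 3 is a number 20 percentage points lower from compound 1 to compound 3 (beyond the scatter), while the step from compound 2 to compound 3 is a number 45 percentage points higher from compound 2 to compound 3 (beyond the scatter), a pair that rests on (the fact that compounds 2 and 3 differ only in the configuration as drawn).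

Compound 4 `CCCCCCc1ccc(NC(=O)N[C@H](C)c2ccccc2)cc1` has not yet been measured in this assay. It differs from compound 2 by propyl in place of hydrogen on a saturated chain carbon, three bonds along the chain from an aromatic carbon. Of the measured steps, only the change of the aromatic substituent from compound 1 to compound 3 bears on this one, and it was modest; the stereochemical step says nothing about chain length. Compound 4 is therefore expected to stay close to compound 2, with a step of a number 6 percentage points lower from compound 2 to compound 4 (within the scatter) if anything a little lower. The estimate for compound 4 in this assay is 25%, between 5% and 55%.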

Compound 4, a percentage reported as activity, at one concentration (the size of the read-out at that concentration, not a potency): 101%
Estimate against measurement, compound 4: 76 percentage points below; the whole stated range lies below it.
By their numbers in this assay, from the lowest: compound 2; then compound 3; then compounds 1 and 4 (each within the scatter of the next).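

In this assay, going by these compounds alone, the alkyl chain on the aromatic ring proves highly sensitive to length at this position: going from propyl to hexyl gives a number 70 percentage points higher from compound 2 to compound 4 (beyond the scatter) and is a large change, whereas the only earlier change to this substituent, a number 20 percentage points lower from compound 1 to compound 3 (beyond the scatter), was modest. The low number of compound 2 therefore does not carry over to the longer chain, even though the stereocentre is drawn the same way in both compounds. Nothing in the available evidence explains this step.

The compounds shown leave open where the number climbs on the way from propyl to hexyl, and whether butyl or pentyl would lie nearer compound 2 or compound 4. They also leave open what hexyl would give with the stereocentre drawn S, as in compound 3, and what an amine or a carboxylic acid would give in place of the propyl.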